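Removing the amino group from a purine cytotoxic series

A few compounds are considered here, and "the series" means these few. Any claim that something is new, unique, unknown or untested is made for them only; others in the source may bear on it.

Measured compounds:
compound 1 `Nc1nc(Cl)c2ncn(Cc3ccccc3CCl)c2n1`, 22900 nM
compound 2 `ClCc1cccc(Cn2cnc3nc(Cl)nc(Cl)c32)c1`, 1730 nM

In a functional assay on BT-549 cells (Homo sapiens) for cytotoxicity, read by sulforhodamine B assay, with a stated time of 48 h (a lower number here means a stronger inhibitor of growth, a higher number a weaker inhibitor of growth), compound 1 gives 22900 nM, the highest number of the two. Among the compounds with values here, its nearest neighbour is compound 2, which in this assay gives 1730 nM, a gap that lies beyond the scatter; the two differ in more than one place, so no single step connects them.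

Compound 3 `ClCc1ccccc1Cn1cnc2c(Cl)ncnc21` is related to compound 1 by one change: hydrogen in place of amino on an aromatic carbon. Nothing measured here isolates that change, so its effect is open. The account therefore expects no step beyond the scatter, with the direction uncertain, and the estimated step of a 1.3-fold lower number from compound 1 to compound 3 (0.10 log units; within the scatter) reflects that. Compound 3 is expected to give about 18000 nM in this assay, within a range from 5000 nM to 60000 nM.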

Compound 3, concentration for total growth inhibition: 5490 nM
Beside the measured number, compound 3's estimate is 3.3-fold (0.52 log units) above it, and the stated range covers the measured number.
By their numbers in this assay, from the lowest: compound 2; then compound 3; then compound 1.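

Within the data shown here, compound 3 gives the first reading of this single change. In this assay hydrogen in place of amino, on the aromatic carbon between two ring nitrogen atoms, gives a 4.2-fold lower number from compound 1 to compound 3 (0.62 log units; beyond the scatter) and that step lies beyond the scatter, so the amino group is not required at this place for growth inhibition in these cells, and the pair reads better without it. Nothing measured here accounts for the step.

On these data alone, whether a methyl group, a hydroxyl group or a methylamino group on the same carbon would read like hydrogen or like amino remains open. Also open, as far as these compounds go, is whether the step carries over to compounds whose other substituents differ from those shared by compound 1 and compound 3.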